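This account rests on a few compounds, and the source may have more. Where it says the series, first, only, none or still open, it means among the compounds named here.

Three related compounds have entries in a functional assay on MDA-MB-231 cells (Homo sapiens) for inhibition, read by MTT assay, with a stated time of 72 h (a lower number here means a stronger inhibitor, a higher number a weaker inhibitor), yet only one of them carries a reading. Compound 1 `CCc1nc2c(C)cc(-c3ccc(CN4CCC[C@H]4CO)cc3)cn2c1NC(=O)OCc1cc(Cl)cc(Cl)c1` has no single number there: its entry is "nd" (no result reported), meaning that no result was reported. Compound 2 `CCc1nc2c(C)cc(-c3ccc(CN4CCN(C)CC4)cc3)cn2c1NC(=O)OCc1cc(Cl)cc(Cl)c1` stands the same way, with the entry "nd" (no result reported). Compound 3 `CCc1nc2c(C)cc(-c3ccc(CNCCO)cc3)cn2c1NC(=O)OCc1cc(Cl)cc(Cl)c1` gives > 20000 nM, which is a limit of the assay and not a number. Going by the values given here, that leaves the limit of > 20000 nM in this assay, at which 1 of the 3 values shown sits, as the only evidence on the scale.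

Compound 4 `CCc1nc2c(C)cc(-c3ccc(CN4CCC[C@H]4CO)cc3)cn2c1NC(=O)OCc1ccc(F)cc1` is still to be measured in this assay. The structural change is a single one: 4-fluorophenyl in place of 3,5-dichlorophenyl on a saturated chain carbon bound to an oxygen next to a carbonyl group. In words, 4-fluorophenyl stands in place of 3,5-dichlorophenyl on a saturated chain carbon bound to an oxygen next to a carbonyl group.

Among the compounds with values here, with no number for compound 1 and no measured step to draw on, no step beyond the usual scatter is expected in this assay, and no direction can be favoured. Within the data shown here, the only guide is compound 3 with its limit of > 20000 nM, so a reading in that region is expected, and it may again be only a limit. Compound 4 is estimated at 15000 nM, with an expected range from 4000 nM to 40000 nM.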

Compound 4, half-maximal inhibitory concentration: > 20000 nM
Compound 4: no number, only a limit (the forecaster's own chance of this, stated with the estimate: 55%); middle value at least 1.3-fold (0.12 log units) away from the limit.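

In this assay compound 4 gives > 20000 nM, which is a limit of the assay and not a number. Going by these compounds alone, compound 1 carries no number there, so no step between compound 1 and compound 4 can be read. The compounds shown leave open whether 4-fluorophenyl in place of 3,5-dichlorophenyl changes the reading at all, and the scale still holds only one kind of evidence: the limit of > 20000 nM in this assay, at which 2 of the 4 values shown sit.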